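A few compounds are considered here, and "the series" means these few. Any claim that something is new, unique, unknown or untested is made for them only; others in the source may bear on it.

Measured in a functional assay on MCF7 cells (Homo sapiens) for antiproliferative activity, read by MTT assay, with a stated time of 48 h; on this read-out higher numbers stand for weaker inhibition and lower numbers for stronger inhibition:
- Compound 1 `CCCCCCCCCn1cc(COC[C@@H]2OC[C@H](N)[C@@H]2O)nn1`: 12400 nM
- Compound 2 `CCCCCCCCCn1cc(COC[C@@H]2OC[C@H](N)[C@H]2O)nn1`: > 128000 nM

From the compounds shown here alone, the value of compound 2 is a limit of this assay, not a number, so its exact standing is unknown. Compound 3 `CCCCCCCCCCCCCCCCn1cc(COC[C@@H]2OC[C@H](N)[C@H]2O)nn1` keeps the configuration of compound 2 and changes only the chain: heptyl in place of hydrogen on a saturated chain carbon, nine bonds along the chain from an aromatic nitrogen. Among the measured compounds shown here, the one measured step, an at least 10-fold higher number from compound 1 to compound 2 (1.01 log units; beyond the scatter), is large and goes with the fact that compounds 1 and 2 differ only in the configuration as drawn. That step bears only indirectly, since it shows how much configuration matters and says nothing about chain length. For the measured compounds named here, no measured step changes the chain, so any forecast here is cautious. A moderate step towards stronger inhibition is expected, an at least 3.2-fold lower number from compound 2 to compound 3 (0.50 log units; beyond the scatter), and another limit remains quite possible. Compound 3 is estimated at 40000 nM, with an expected range of 8000 nM to 160000 nM.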

Compound 3, half-maximal inhibitory concentration: 2260 nM
Compound 3: middle estimate off by 18-fold (1.25 log units), on the high side, outside the stated range (below it).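

In this assay, heptyl in place of hydrogen on a saturated chain carbon, nine bonds along the chain from an aromatic nitrogen, brings a large gain in inhibition: an at least 56-fold lower number from compound 2 to compound 3 (1.75 log units; beyond the scatter). From the compounds shown here alone, the true size of this step stays unknown because the value of compound 2 is a limit and not a number: the limit of > 128000 nM in this assay, at which 1 of the 3 values shown sits. The configuration of compound 2 therefore does not rule out inhibition on this read-out, as compound 3 carries it and gives 2260 nM.

Compound 1 and compound 3 differ in two places, so they show neither which configuration is better with the longer chain nor whether heptyl would bring the same gain to compound 1. Also open, going by these compounds, is what a still longer chain, or an amine or carboxylic acid at the end of the chain, would do.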